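A few compounds are considered here, and "the series" means these few. Any claim that something is new, unique, unknown or untested is made for them only; others in the source may bear on it.

In a functional assay on MCF7 cells (Homo sapiens) for antiproliferative activity, read by MTT assay, with a stated time of 48 h (a lower number here means a stronger inhibitor, a higher number a weaker inhibitor), compound 1 `COc1ccc2nc(NC(c3cn(-c4ccccc4)nc3-c3ccc(Cl)cc3)c3c(O)ccc4ccccc34)sc2c1` gives 23700 nM and compound 2 `COc1ccc(-c2nn(-c3ccccc3)cc2C(Nc2nc3ccc(OC)cc3s2)c2c(O)ccc3ccccc23)cc1` gives 41800 nM. Going by the values given here, compound 2 therefore stands within the scatter of compound 1, the only other measured compound. Compound 3 `COc1cccc(-c2nn(-c3ccccc3)cc2C(Nc2nc3ccc(OC)cc3s2)c2c(O)ccc3ccccc23)c1`, not yet measured, differs from compound 2 by this change: 3-methoxyphenyl in place of 4-methoxyphenyl on an aromatic carbon. In words, this is 3-methoxyphenyl in place of 4-methoxyphenyl on an aromatic carbon, with the same atoms joined differently. Among the compounds with values here, no measured step moves a methoxy group in this way, so the evidence is indirect. Within the data shown here, the only measured step, methoxy in place of chloro on an aromatic carbon, is a 1.8-fold higher number from compound 1 to compound 2 (0.25 log units; within the scatter). On that basis, no step beyond the scatter is expected in this assay, and no direction can be assigned. The expected step is a 1.2-fold lower number from compound 2 to compound 3 (0.08 log units; within the scatter). For compound 3 the estimated value is 35000 nM, with an expected range of 14000 nM to 85000 nM.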

Compound 3, half-maximal inhibitory concentration: 62600 nM
Compound 3: middle estimate off by 1.8-fold (0.25 log units), on the low side, and the stated range covers the measured number.
By their numbers in this assay, from the lowest: compounds 1, 2 and 3 (each within the scatter of the next, the first and the last beyond it).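

In this assay, going by these compounds alone, 3-methoxyphenyl in place of 4-methoxyphenyl on the aromatic carbon next to the ring nitrogen gives a 1.5-fold higher number from compound 2 to compound 3 (0.18 log units; within the scatter) and so does not separate the two compounds at this position. 3-methoxyphenyl in place of 4-chlorophenyl at the same carbon gives a 2.6-fold higher number from compound 1 to compound 3 (0.42 log units; beyond the scatter) as the first step to pass the scatter, although only modestly, whereas the methoxy and chloro pair sharing the 4-position stayed within it. No evidence on these compounds accounts for these numbers.

The compounds shown leave open how this position responds to a phenyl ring carrying an amine or a carboxylic acid, or to a longer chain in place of the methoxy group. On these data alone, whether these steps would read the same with the methoxy group on the shared core replaced also stays open.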